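This account rests on a few compounds, and the source may have more. Where it says the series, first, only, none or still open, it means among the compounds named here.

Measured in a functional assay on A549 cells (Homo sapiens) for antiproliferative activity, read by MTT assay; on this read-out higher numbers stand for weaker inhibition and lower numbers for stronger inhibition:
Compound 1 `Cn1c(=O)c(=O)n(C2CCCC2)c2nc(N/N=C/c3ccccc3)ncc21`: > 100000 nM (a limit of the assay, not a number)
Compound 2 `Cn1c(=O)c(=O)n(C2CCCC2)c2nc(N/N=C/c3cccc(Cl)c3Cl)ncc21`: 39100 nM

Among the compounds with values here, compound 2 holds the only actual number so far, and its inhibition is the stronger of the two. Within the data shown here, the single measured step is an at least 2.5-fold lower number from compound 1 to compound 2 (0.40 log units; beyond the scatter). On these data alone, its true size stays open because of the limit of > 100000 nM in this assay, at which 1 of the 2 values shown sits.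

The next compound, compound 3 `Cn1c(=O)c(=O)n(C2CCCC2)c2nc(N/N=C/c3ccco3)ncc21`, keeps the shared core and changes one group: furan-2-yl in place of 2,3-dichlorophenyl on a carbon with a double bond to nitrogen. Here, furan-2-yl takes the place of 2,3-dichlorophenyl on a carbon with a double bond to nitrogen.

Among the measured compounds shown here, only one measured step bears on this change, and it is an imperfect guide, since furan-2-yl has not yet been tested. Like compound 1, compound 3 lacks the 2,3-dichlorophenyl group, whose arrival gave an at least 2.5-fold lower number from compound 1 to compound 2 (0.40 log units; beyond the scatter). A modest move towards higher numbers in this assay is therefore expected, and the assay may again report only a limit. The expected change is a 2.2-fold higher number from compound 2 to compound 3 (0.34 log units; beyond the scatter). For compound 3 the estimated value is 85000 nM, with an expected range from 35000 nM to 200000 nM.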

Compound 3, half-maximal inhibitory concentration: > 100000 nM
Compound 3: a limit, no number; the forecaster's own chance of this, stated with the estimate: 55%; middle value at least 1.1-fold (0.07 log units) away from the limit.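

In this assay compound 3 gives > 100000 nM, which is a limit of the assay and not a number. Putting furan-2-yl in place of 2,3-dichlorophenyl gives an at least 2.5-fold higher number from compound 2 to compound 3 (0.40 log units; beyond the scatter), so among the three groups shown on this carbon, only 2,3-dichlorophenyl gives an actual number, and the hydrogen-bond acceptor that furan-2-yl brings does not restore a readable value. The full size of this step stays open, and the step from compound 1 to compound 3 cannot be read, because of the assay limit: the limit of > 100000 nM in this assay, at which 2 of the 3 values shown sit.

The compounds shown do not tell whether a single chlorine on the phenyl ring would be enough, or whether a methoxy group, a nitrile or a pyridine ring at this carbon would also give a readable number. Also open, on these data alone, is whether an amine placed elsewhere on the shared core would change how these groups rank, and how compound 1 and compound 3 compare with each other.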